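The source may hold more compounds than are shown below. What is called first, only, known or untested is meant among the compounds shown, and "the series" means these compounds.

Measured in an in vitro assay on HEK-tsA201 cells for antagonist activity at Neuronal acetylcholine receptor; alpha3/beta4 (Homo sapiens), read by fluorescence and calcium flux; on this read-out lower numbers stand for stronger inhibition and higher numbers for weaker inhibition:
compound 1, `CCCCCCNc1cccc(NC(=O)c2ccc(OCCC)cc2)n1`, gives > 100000 nM, a limit of the assay.
compound 2, `CCCOc1ccc(C(=O)Nc2cccc(Nc3ccccc3F)n2)cc1`, gives > 100000 nM, a limit of the assay.
compound 3, `CCCOc1ccc(C(=O)Nc2cccc(Nc3cccc(F)c3)n2)cc1`, gives > 100000 nM, a limit of the assay.

Compound 3 therefore stands at the limit (the limit of > 100000 nM in this assay, at which 3 of the 3 values shown sit), with nothing to rank it against compound 1 or compound 2. The steps a step that the two limits leave unreadable from compound 1 to compound 2, a step that the two limits leave unreadable from compound 1 to compound 3 and a step that the two limits leave unreadable from compound 2 to compound 3 are all unreadable, since both ends of each sit at that limit.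

Compound 4, `CCCOc1ccc(C(=O)Nc2cccc(NCc3ccccc3)n2)cc1`, differs from compound 3 by benzyl in place of 3-fluorophenyl on a nitrogen on an aromatic ring. Going by the values given here, no measured step bears readably on this exchange; all three exchanges on the same nitrogen left the limit untouched, so no size or direction can be anticipated beyond the scatter in this assay. Compound 4 is expected at 150000 nM, estimated between 40000 nM and 600000 nM. The expected step that the limit leaves unreadable from compound 3 to compound 4 is thus essentially none, most likely another limit.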

Compound 4, half-maximal inhibitory concentration: > 100000 nM
Compound 4: only a limit was reported (the forecaster's own chance of this, stated with the estimate: 85%); the middle value is on the limit's open side.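

No new step can be read for compound 4 against compound 1, compound 2 or compound 3, because all four sit at a shared limit: the limit of > 100000 nM in this assay, at which 4 of the 4 values shown sit.

The compounds shown leave open how these four rank and whether any group on this nitrogen gives measurable inhibition.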